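From compound 1 to compound 3: adding a methyl

The compounds below may be only part of what the source reports. "The series", "measured", "known", "first", "only" and "open" are said of these compounds alone.

Going by the values given here, in a functional assay on the whole organism with Canis familiaris (Canis lupus familiaris) as the target (a higher number here means that more compound is needed for the effect, a lower number that less compound is needed), compound 1 `c1ccc(-c2nc3ccc[nH]c-3n2)cc1` gives 8 mg/kg and stands as the higher of the two numbers measured so far. Compound 2 `CSc1ccc(-c2nc3ccc[nH]c-3n2)cc1` gives 1.9 mg/kg there. Compound 3 `Cc1cccc(-c2nc3ccc[nH]c-3n2)c1` differs from compound 1 in one place. The change methyl in place of hydrogen on an aromatic carbon puts methyl in place of hydrogen on an aromatic carbon, meta to a group of 9 heavy atoms. Among the compounds with values here, the only measured step that bears on it is a 4.2-fold lower number from compound 1 to compound 2 (0.62 log units; beyond the scatter) for methylsulfanyl in place of hydrogen on an aromatic carbon, a modest move. Within the data shown here, no measured compound carries this methyl, so that step is only a loose guide. A smaller move in the same direction is expected in this assay and it may not clear the scatter. The estimate amounts to a 1.6-fold lower number from compound 1 to compound 3 (0.20 log units; within the scatter) as an expected step. Compound 3 is estimated at 5 mg/kg with an expected range from 2.5 mg/kg to 11 mg/kg for now.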

Compound 3, dose for half-maximal effect: 2.8 mg/kg
Compound 3: middle estimate off by 1.8-fold (0.25 log units), on the high side; measured number inside the range.
By their numbers in this assay, from the lowest: compounds 2 and 3 (each within the scatter of the next); then compound 1.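

In this assay methyl in place of hydrogen on an aromatic carbon, meta to a group of 9 heavy atoms, gives a 2.9-fold lower number from compound 1 to compound 3 (0.46 log units; beyond the scatter) from this one change. A group of 1 heavy atom, with 0 hydrogen-bond donors and 0 hydrogen-bond acceptors, is therefore enough at this position to move the number beyond the scatter, and the methylsulfanyl change, with a 4.2-fold lower number from compound 1 to compound 2 (0.62 log units; beyond the scatter) as its step, is no longer the only substitution seen to lower it. No measured property of these compounds is available to account for the step.

On these data alone, whether an amine, a carboxylic acid or a longer chain at this position would lower the number as well stays open. As far as these compounds go, whether methyl on another carbon of the same ring gives a similar step also stays open.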